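Opening the pyrrolidine ring: an estimate for compound 4

The compounds below may be only part of what the source reports. "The series", "measured", "known", "first", "only" and "open" are said of these compounds alone.

Three compounds have been measured in an assay on HeLa cells for inhibition of sphingosine-1-phosphate transporter SPNS2 (Mus musculus), read by LC-MS, tested at 2 uM; on this read-out lower numbers stand for less inhibition and higher numbers for more inhibition at the one concentration tested (going by the name of the read-out):
compound 1 `CCCCCCCCCCc1ccc(-c2noc(CC3CNC3)n2)cc1` gives 63%;
compound 2 `CCCCCCCCCCc1ccc(-c2noc([C@@H]3CCNC3)n2)cc1` gives 62%;
compound 3 `CCCCCCCCCCc1ccc(-c2noc([C@@H]3CCCN3)n2)cc1` gives 21%.

Compound 2 stands second highest of the three. Its nearest neighbour is compound 1, with a number 1 percentage points lower from compound 1 to compound 2 (within the scatter); its furthest is compound 3, with a number 41 percentage points lower from compound 2 to compound 3 (beyond the scatter). Compound 4 `CCCCCCCCCCc1ccc(-c2noc(C(Cl)CCN)n2)cc1` differs from compound 2 in one place: a group of 5 heavy atoms (3 carbon, 1 nitrogen, 1 chlorine; no ring) in place of a group of 5 heavy atoms (4 carbon, 1 nitrogen; one five-membered non-aromatic ring with 1 hetero atom), on an aromatic carbon. Going by the values given here, two steps bear on this change. Swapping one small cyclic amine for another left the read-out unchanged, as seen from compound 1 to compound 2, while moving to pyrrolidin-2-yl produced a large drop, as seen from compound 2 to compound 3. Among the compounds with values here, no measured step involves an open chain or a chlorine, so the expectation is uncertain; a moderate decrease is expected. Compound 4 is expected to give 45%, between 15% and 70%. The expected step is a number 17 percentage points lower from compound 2 to compound 4 (beyond the scatter).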

Compound 4, a percentage reported as inhibition, at one concentration (the size of the read-out at that concentration, not a potency): 5%
Beside the measured number, compound 4's estimate is 40 percentage points above it; the measured number lies below the stated range.
By their numbers in this assay, from the lowest: compound 4; then compound 3; then compounds 2 and 1 (each within the scatter of the next).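

In this assay, the open chain carrying chlorine loses nearly all of the read-out, with a number 57 percentage points lower from compound 2 to compound 4 (beyond the scatter) and a number 58 percentage points lower from compound 1 to compound 4 (beyond the scatter), so at this aromatic carbon neither cyclic amine can be swapped for this no-ring group without loss, although the heavy-atom count is the same. The chain also goes further than the pyrrolidin-2-yl group, with a number 16 percentage points lower from compound 3 to compound 4 (beyond the scatter), so the earlier drop had not reached the lowest level at this position. Nothing available bears on why the number falls. As far as these compounds go, whether the loss belongs to the opened ring or to the chlorine remains open, and a plain open amine chain without chlorine would separate the two.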